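Chloro-to-hydroxy swap on the aryl ring of compound 1

The source may report more compounds than this note shows. Statements on the series, on what has been measured and on what is new or still open speak of the compounds shown alone.

Measured so far:
compound 1, `CCOC(=O)c1cnn(-c2nc(-c3ccccc3Cl)c(C#N)c(=O)n2C)c1N`, 93 ug/mL
compound 2, `CSc1nc(-c2ccccc2O)c(C#N)c(=O)n1C`, 58 ug/mL

In a functional assay, with a stated time of 150 min (on this read-out higher numbers stand for weaker inhibition and lower numbers for stronger inhibition), compound 1 gives 93 ug/mL, the highest of the two numbers recorded. Its nearest neighbour is compound 2, which in this assay gives 58 ug/mL; the gap between the two lies within the scatter, so no order between them can be stated.

Compound 3, `CCOC(=O)c1cnn(-c2nc(-c3ccccc3O)c(C#N)c(=O)n2C)c1N`, keeps the core of compound 1 and differs in one place: hydroxy in place of chloro on an aromatic carbon. Among the measured compounds shown here, no step between measured compounds isolates this change, and compound 2, though it carries the same 2-hydroxyphenyl, sits on a different core, so it gives no direct reading of the swap.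

With only the two numbers recorded and both within the scatter of each other, the expected step of a 1.2-fold lower number from compound 1 to compound 3 (0.09 log units; within the scatter) is small, with no direction beyond the scatter. Compound 3 is therefore estimated at 75 ug/mL, within a range of 30 ug/mL to 190 ug/mL.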

Compound 3, half-maximal inhibitory concentration: 64 ug/mL
For compound 3 the middle estimate is 1.2-fold (0.07 log units) above the measured one; low and high end bracket the measured number.
By their numbers in this assay, from the lowest: compounds 2, 3 and 1 (each within the scatter of the next).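

In this assay, among the compounds shown here, the change from 2-chlorophenyl to 2-hydroxyphenyl on the shared core gives a 1.5-fold lower number from compound 1 to compound 3 (0.16 log units; within the scatter) and is the first direct reading of this position. On this evidence, hydroxy can stand in place of chloro on this aromatic carbon, with its added hydrogen-bond donor and acceptor, without a step beyond the scatter. No measured property bears on this result.

On these data alone, whether an amine or a methoxy group at this place, or a carboxylic acid in place of the ethyl ester, would give a step beyond the scatter stays open. Compound 2 carries the same 2-hydroxyphenyl on a different core, so the part played by the rest of the molecule also remains unresolved.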